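The source may report more compounds than this note shows. Statements on the series, on what has been measured and on what is new or still open speak of the compounds shown alone.

In a functional assay on DU-145 cells (Homo sapiens) for inhibition, read by trypan blue exclusion, with a stated time of 96 h (on this read-out higher numbers stand for weaker inhibition of growth and lower numbers for stronger inhibition of growth), three compounds have been measured so far. Compound 1 `Cc1ccc(S/C(=C/c2c[nH]c3ccccc23)C(=O)c2ccc(Br)cc2)cc1` gives 10000 nM and compound 2 `COc1ccccc1/C=C(/SCc1ccc(F)cc1)C(=O)c1ccc(Br)cc1` gives 10000 nM on this scale, while compound 3 `COc1ccccc1/C=C(/Sc1ccc(C)cc1)C(=O)c1ccc(Br)cc1` gives 9000 nM and so stands level with both, since its gaps to them lie within the scatter.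

The next compound to be tested is compound 4 `Cc1ccc(S/C(=C/c2ccc(N(C)C)cc2)C(=O)c2ccc(Br)cc2)cc1`, which differs from compound 3 by one swap (4-(dimethylamino)phenyl in place of 2-methoxyphenyl on a double-bonded chain carbon bound to a double-bonded chain carbon) and keeps the rest of the structure unchanged.

For the measured compounds named here, two measured steps bear on this swap. The closer one is a 1.1-fold lower number from compound 1 to compound 3 (0.05 log units; within the scatter) at that same place on the chain, and the other is a 1.1-fold lower number from compound 2 to compound 3 (0.05 log units; within the scatter) on the sulfur. Both are small, so changing either of these groups has not yet moved the number beyond the scatter. However, no measured compound carries the 4-(dimethylamino)phenyl group, and only one swap at this place has been seen, so the evidence is thin.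

No step beyond the scatter is therefore expected in this assay, although a wide range is sensible. The estimated step is a 1.1-fold lower number from compound 3 to compound 4 (0.05 log units; within the scatter) and it is expected to be small. For compound 4 the estimated value is 8000 nM with an expected range from 3000 nM to 20000 nM in this test.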

Compound 4, concentration for 50% growth inhibition: > 100000 nM
Compound 4: a limit, no number; the forecaster's own chance of this, stated with the estimate: 15%; middle value at least 12-fold (1.09 log units) away from the limit.
By their numbers in this assay, from the lowest: compounds 3, 1 and 2 (each within the scatter of the next). At a limit, above all of these: compound 4.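

In this assay, the earlier swap at this place, on a double-bonded chain carbon bound to a double-bonded chain carbon, gave a 1.1-fold lower number from compound 1 to compound 3 (0.05 log units; within the scatter), so the place looked as if it could take different groups without any change in the number. The new group shows otherwise, since 4-(dimethylamino)phenyl gives an at least 11-fold higher number from compound 3 to compound 4 (1.04 log units; beyond the scatter) and an at least 10-fold higher number from compound 1 to compound 4 (1.00 log units; beyond the scatter), which means much weaker inhibition of growth and shows that the group at this place can matter a great deal in this series. Compound 4 is read only as a limit of the assay, not as a number: the limit of > 100000 nM in this assay, at which 1 of the 4 values shown sits.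

The compounds shown cannot separate the effect of the dimethylamino part from that of the rest of the 4-(dimethylamino)phenyl group, and a plain phenyl, a 4-aminophenyl or a 4-methoxyphenyl at this place would help to make that separation. They also leave open whether the same swap would act in the same way with 4-fluorobenzyl on the sulfur in place of 4-methylphenyl, and whether any group at this place gives stronger inhibition of growth than the groups seen so far.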